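Swapping a nitrogen out of the linker to the trifluoromethylphenyl ring

A few compounds are considered here, and "the series" means these few. Any claim that something is new, unique, unknown or untested is made for them only; others in the source may bear on it.

Measured so far:
compound 1 `COc1cc(Cl)cc(-c2nn(-c3cccc(NC(=O)c4ccc(Cl)c(Cl)c4)c3)cc2-c2ccncc2)c1`: 57.7%
compound 2 `COc1cc(Cl)cc(-c2nn(-c3cccc(NC(=O)Nc4cccc(C(F)(F)F)c4)c3)cc2-c2ccncc2)c1`: 0.3%

In a functional assay on MCF7 cells (Homo sapiens) for inhibition, read by sulforhodamine B assay, with a stated time of 48 h, tested at 10 uM (a lower number here means a stronger effect, a higher number a weaker effect of the compound at the concentration tested), compound 2 gives 0.3% and stands lowest of the two measured numbers; its nearest neighbour is compound 1, whose number is higher, so that on this reading compound 2 shows the stronger effect. The step between them is a number 57.4 percentage points lower from compound 1 to compound 2 (beyond the scatter). That step, however, changes two things at once: the ring that hangs on the carbonyl carbon and the nitrogen that links it.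

Compound 3 `COc1cc(Cl)cc(-c2nn(-c3cccc(NC(=O)c4cccc(C(F)(F)F)c4)c3)cc2-c2ccncc2)c1` has not yet been measured. It differs from compound 2 in one place: 3-(trifluoromethyl)phenyl in place of (3-(trifluoromethyl)phenyl)amino on a carbonyl carbon. It keeps the ring of compound 2 but joins it to the carbonyl carbon in the manner of compound 1. For the measured compounds named here, the only measured step that bears on this is the one from compound 1 to compound 2, and it is large, yet it does not separate the two changes it contains. A number somewhere between the two measured compounds is therefore expected, with a wide range. For compound 3 the expected step is a number 29.7 percentage points higher from compound 2 to compound 3 (beyond the scatter), giving an estimate of 30%, between 0% and 65%.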

Compound 3, a percentage reported as activity, at one concentration (the size of the read-out at that concentration, not a potency): 39.4%
Estimate against measurement, compound 3: 9.4 percentage points below; the measured number falls inside the stated range.
By their numbers in this assay, from the lowest: compound 2; then compound 3; then compound 1.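

In this assay, removing only the nitrogen on the carbonyl carbon while keeping the trifluoromethyl-bearing ring gives a number 39.1 percentage points higher from compound 2 to compound 3 (beyond the scatter), a large move towards a weaker effect. Changing only the ring, with the carbonyl carbon joined directly to it in both compounds, gives a number 18.3 percentage points lower from compound 1 to compound 3 (beyond the scatter), a modest move towards a stronger effect. The two changes combined in the step from compound 1 to compound 2 can now be read separately: each one, taken alone, moves the number in the same direction, and the nitrogen link accounts for the larger step.

As far as these compounds go, it remains open whether the effect of this link depends on the nitrogen itself or on its hydrogen, which a methylated nitrogen, an oxygen atom or a methylene group in the same place could help to separate. Nothing shown here explains why either change alters the effect of the compounds on these cells.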